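This account rests on a few compounds, and the source may have more. Where it says the series, first, only, none or still open, it means among the compounds named here.

Measured so far:
Compound 1 `OC[C@H]1O[C@@H](n2cnc3c(NCc4ccccc4Br)ncnc32)[C@H](O)[C@@H]1O` gives 10000 nM in a functional assay on K562 cells (Homo sapiens) for antiproliferative activity, with a stated time of 72 h; on this read-out lower numbers stand for stronger inhibition and higher numbers for weaker inhibition.
Compound 2 `OC[C@H]1O[C@@H](n2cnc3c(NCc4ccc(Cl)cc4Cl)ncnc32)[C@H](O)[C@@H]1O` gives 106000 nM in this assay.

Compound 1 stands lowest of the two numbers in this assay, and the nearest to it is compound 2, which sits higher as shown in an 11-fold higher number from compound 1 to compound 2 (1.03 log units; beyond the scatter). The step now followed leads from compound 1 to compound 3 `OC[C@H]1O[C@@H](n2cnc3c(NCc4c(F)ccc(F)c4F)ncnc32)[C@H](O)[C@@H]1O`, and the change is 2,3,6-trifluorophenyl in place of 2-bromophenyl on a saturated chain carbon bound to a nitrogen on an aromatic ring. Within the data shown here, only one measured step bears on it: the move from compound 1 to compound 2, which swaps one halogenated phenyl for another on the same saturated chain carbon and gave an 11-fold higher number from compound 1 to compound 2 (1.03 log units; beyond the scatter). A further halogen swap at the same place is therefore expected to raise the number again, likely beyond the scatter but by less than that step, a 3.0-fold higher number from compound 1 to compound 3 (0.48 log units; beyond the scatter). Compound 3 is thus estimated at 30000 nM, in a range from 8000 nM to 120000 nM.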

Compound 3, half-maximal inhibitory concentration: > 166000 nM
Compound 3: no number, only a limit; the forecaster's own chance of this, stated with the estimate: 20%; at least 5.5-fold (0.74 log units) between middle value and limit.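

Compound 3 gives no number in this assay, only a limit: the limit of > 166000 nM in this assay, at which 1 of the 3 values shown sits.

Even so, 2,3,6-trifluorophenyl in place of 2-bromophenyl on the saturated chain carbon gives an at least 16-fold higher number from compound 1 to compound 3 (1.22 log units; beyond the scatter), so a second replacement of the 2-bromophenyl also ends far from compound 1, which stands as the most active of the three. Against the 2,4-dichlorophenyl the step reads an at least 1.5-fold higher number from compound 2 to compound 3 (0.19 log units; that floor lies within the scatter), so compound 2 and compound 3 cannot be put in order.

As far as these compounds go, all three compounds carry a halogenated phenyl at this place, and whether an unsubstituted phenyl, a methoxyphenyl or a pyridine ring there would bring the number below that of compound 1 stays open. Also open, from the compounds shown here alone, is how far the true value of compound 3 lies past its limit.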